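Adding a Methoxyphenyl Group Where Fluorophenyl Changed Nothing

The source may hold more compounds than are shown below. What is called first, only, known or untested is meant among the compounds shown, and "the series" means these compounds.

Compound 1 `CC(C)(C)Cc1csc(N)c1C(=O)c1ccc(Cl)cc1` was tested in an assay on CHO cells for displacement of a labelled ligand from adenosine receptor A1 (Homo sapiens), read by scintillation counting, tested at 10 uM (on this read-out higher numbers stand for more inhibition at the one concentration tested (going by the name of the read-out) and lower numbers for less inhibition), where compound 1 gives 1%. Two close relatives were measured alongside it. Compound 2 `Cc1sc(N)c(C(=O)c2ccc(Cl)cc2)c1-c1ccccc1` gives 1%, and compound 3 `CC(C)(C)Cc1c(-c2ccc(F)cc2)sc(N)c1C(=O)c1ccc(Cl)cc1` gives 1%. All three sit level with one another within the scatter, so compound 1 stands on the same low plateau as compound 2 and compound 3. Among the measured compounds shown here, the only single-point step among them puts 4-fluorophenyl in place of hydrogen on an aromatic carbon of the shared core, and it gives no change at the digits printed from compound 1 to compound 3 (within the scatter).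

Compound 4 `COc1cccc(-c2sc(N)c(C(=O)c3ccc(Cl)cc3)c2CC(C)(C)C)c1` has not yet been measured. It differs from compound 1 by 3-methoxyphenyl in place of hydrogen on an aromatic carbon. The new group sits on the same aromatic carbon, next to the ring sulfur, that carries the 4-fluorophenyl in compound 3. For the measured compounds named here, that step is the one piece of evidence bearing on the change, and it showed no movement. A different six-membered aromatic ring on that carbon is expected to behave alike, so the expected step is a number 1 percentage points higher from compound 1 to compound 4 (within the scatter), because no change at the digits printed from compound 1 to compound 3 (within the scatter) was seen. Compound 4 is therefore estimated at 2%, with a range from -6% to 12%.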

Compound 4, a percentage reported as inhibition, at one concentration (the size of the read-out at that concentration, not a potency): 1%
The estimate for compound 4 lay 1 percentage points above the measured number; measured number inside the range.
By their numbers in this assay, from the lowest: compounds 1, 2, 3 and 4 (each within the scatter of the next).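

In this assay the 3-methoxyphenyl group on this aromatic carbon gives no change at the digits printed from compound 1 to compound 4 (within the scatter), so a second substituent bearing a six-membered aromatic ring of carbon only now leaves the result level with hydrogen at this position. Exchanging the two substituents gives no change at the digits printed from compound 3 to compound 4 (within the scatter), which means that neither the different substituent on the added ring nor the oxygen that 3-methoxyphenyl brings separates these two compounds in this read-out. With all four compounds level and so low, nothing here identifies any feature of the series that raises the number, and no other measurement is available to explain the flat result.

The compounds shown leave open whether a group of a different kind on this same carbon, such as a carboxylic acid, a dimethylaminomethyl group or a longer hydroxyalkyl chain, would read any differently from hydrogen. They also leave open whether the 3-methoxyphenyl group would still make no difference if the 4-chlorophenyl on the carbonyl were replaced by a group such as 3-(trifluoromethyl)phenyl.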